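Adding a Chlorine Beside Fluorine on the Sulfonyl Ring

The source may hold more compounds than are shown below. What is called first, only, known or untested is meant among the compounds shown, and "the series" means these compounds.

Of the compounds shown here, three sharing one core have been measured in an assay on isolated protein for displacement of a labelled ligand from metabotropic glutamate receptor 5 (Homo sapiens), with a stated time of 60 min, tested at 1 uM; on this read-out lower numbers stand for less inhibition and higher numbers for more inhibition at the one concentration tested (going by the name of the read-out). Compound 1 `CC1CCN(c2c(S(=O)(=O)c3cccc(F)c3)cnc3ccc(F)cc23)CC1` gives 76%, compound 2 `Cc1ccc2ncc(S(=O)(=O)c3ccc(F)cc3)c(N3CCC(C)CC3)c2c1` gives 90%, and compound 3 `CC1CCN(c2c(S(=O)(=O)c3ccc(F)cc3)cnc3ccc(F)cc23)CC1` gives 87%. Compound 3 therefore stands second of the three: its number and that of compound 2 lie within the usual scatter of each other, while its distance from compound 1 is beyond it, as the step of a number 11 percentage points higher from compound 1 to compound 3 (beyond the scatter) shows. The step of a number 3 percentage points lower from compound 2 to compound 3 (within the scatter) shows how little a change at the far side of the core mattered.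

Compound 4 `CC1CCN(c2c(S(=O)(=O)c3ccc(F)c(Cl)c3)cnc3ccc(F)cc23)CC1` differs from compound 3 in one place: chloro in place of hydrogen on an aromatic carbon. Among the measured compounds shown here, no measured step adds a group to this ring; the step from compound 1 to compound 3 only moved the fluoro group on it, and the step from compound 2 to compound 3 touched another ring. With the ring already bearing its fluoro group in the arrangement of compound 3, little shift in this assay is expected, so compound 4 is estimated at 85%, between 70% and 96%, a step of a number 2 percentage points lower from compound 3 to compound 4 (within the scatter) expected to lie within the scatter.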

Compound 4, a percentage reported as inhibition, at one concentration (the size of the read-out at that concentration, not a potency): 95%
Compound 4: the middle estimate sits 10 percentage points below what was measured, and the stated range covers the measured number.
By their numbers in this assay, from the lowest: compound 1; then compounds 3, 2 and 4 (each within the scatter of the next).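

This is the first compound shown with a second group on the sulfonyl ring, and with chloro ortho to a fluoro group the number in this assay is level (a number 8 percentage points higher from compound 3 to compound 4 (within the scatter)), so the added atom can be said neither to raise nor to lower the number. The 3-chloro-4-fluorophenyl group also stands clear of the 3-fluorophenyl group of compound 1 (a number 19 percentage points higher from compound 1 to compound 4 (beyond the scatter)), which shows that the ring can carry a group at the position held by fluoro in compound 1 when a 4-fluoro group is also present. Nothing available explains these numbers.

From the compounds shown here alone, whether a methoxy group or a nitrile in place of chloro would give a similar number remains open. Also open, going by these compounds, is whether compound 3 and compound 4 would remain close in a full potency measurement rather than at one concentration.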